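The source may report more compounds than this note shows. Statements on the series, on what has been measured and on what is new or still open speak of the compounds shown alone.

Working notes on a pyrazole urea series tested in a functional assay on HOP-62 cells (Homo sapiens) for inhibition, read by sulforhodamine B assay, with a stated time of 48 h; on this read-out lower numbers stand for higher toxicity in this test and higher numbers for lower toxicity in this test.

Compound 1 `COc1cc(-c2nn(-c3cccc(NC(=O)Nc4cc(C(F)(F)F)cc(C(F)(F)F)c4)c3)cc2-c2ccncc2)ccc1Cl` gives 2950 nM in this assay. Compound 2 `O=C(Nc1cccc(-n2cc(-c3ccncc3)c(-c3ccc(Cl)c(O)c3)n2)c1)Nc1cc(C(F)(F)F)cc(C(F)(F)F)c1` carries hydrogen in place of methyl on an oxygen on an aromatic ring relative to compound 1, and in this assay compound 2 gives 4070 nM; the step is a 1.4-fold higher number from compound 1 to compound 2 (0.14 log units; within the scatter). Compound 3 `COc1cc(-c2nn(-c3cccc(NC(=O)Nc4ccc(Cl)c(C(F)(F)F)c4)c3)cc2-c2ccncc2)ccc1Cl` differs from compound 1 in the urea aryl part; the difference between the two cores is not broken down here. In this assay compound 3 gives 31000 nM, the highest of the three numbers, beyond the scatter from both compound 1 and compound 2.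

Compound 4 `O=C(Nc1cccc(-n2cc(-c3ccncc3)c(-c3ccc(Cl)c(O)c3)n2)c1)Nc1ccc(Cl)c(C(F)(F)F)c1` stands to compound 3 as compound 2 stands to compound 1: the change is hydrogen in place of methyl on an oxygen on an aromatic ring, the same kind of change as before, at a place described in identical words for both pairs. Since the earlier instance of this change gave only a 1.4-fold higher number from compound 1 to compound 2 (0.14 log units; within the scatter), a step within the scatter, the expectation is that the step of a 1.3-fold higher number from compound 3 to compound 4 (0.11 log units; within the scatter) is likewise small. Compound 4 is therefore expected to give about 40000 nM in this assay, with a plausible range of 15000 nM to 100000 nM.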

Compound 4, concentration lethal to 50% of the cells: > 32500 nM
Compound 4: only a limit was reported; the forecaster's own chance of this, stated with the estimate: 10%; the middle value is on the limit's open side.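

In this assay compound 4 gives > 32500 nM, which is a limit of the assay and not a number. The step can therefore be read only as a floor, an at least 1.0-fold higher number from compound 3 to compound 4 (0.02 log units; that floor lies within the scatter), and this fits a step within the scatter as well as a larger one for 4-chloro-3-methoxyphenyl to 4-chloro-3-hydroxyphenyl on this core. The pair of cores thus gives no sign that the change acts differently from one core to the other, but it does not show that the change carries over unaltered: the same change on two cores in this assay, a 1.4-fold higher number (0.14 log units; within the scatter) from compound 1 to compound 2 and an at least 1.0-fold higher number (0.02 log units; that floor lies within the scatter) from compound 3 to compound 4; the limit leaves it open whether they differ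

The compounds shown leave open how far the number for compound 4 lies past its limit, and whether methoxy to hydroxy would read the same with other urea aryl parts. They also leave open how this assay would read with an amine or a carboxylic acid in place of the hydroxy group, or with a longer chain such as ethoxy in place of the methoxy group.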